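The compounds below may be only part of what the source reports. "The series", "measured", "known", "first", "only" and "open" are said of these compounds alone.

Compound 1 `CCCCCCc1cc2cn([C@H]3C[C@H](O)[C@@H](CO)O3)c(=O)nc2o1`, compound 2 `CCCCCCCCc1cc2cn([C@H]3C[C@H](O)[C@@H](CO)O3)c(=O)nc2o1` and compound 3 `CCCCCCCCCCc1cc2cn([C@H]3C[C@H](O)[C@@H](CO)O3)c(=O)nc2o1` share one core and differ only in the length of the saturated chain on its aromatic carbon. In a functional assay on HEL cells (Homo sapiens) for cytotoxicity, read by microscopy (a higher number here means that more compound is tolerated, a lower number that less compound is tolerated), compound 1 gives > 50000 nM, which is a limit of the assay rather than a number. In this assay compound 2 likewise gives only a limit, > 50000 nM. Compound 3 stands at the same limit, > 50000 nM. Because all three sit at the limit of > 50000 nM in this assay, at which 3 of the 3 values shown sit, the three steps among them cannot be read: a step that the two limits leave unreadable from compound 1 to compound 2, a step that the two limits leave unreadable from compound 1 to compound 3 and a step that the two limits leave unreadable from compound 2 to compound 3.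

Compound 4 `C=CCCCCCCc1cc2cn([C@H]3C[C@H](O)[C@@H](CO)O3)c(=O)nc2o1` is the next member, not yet measured. Its difference from compound 3 is vinyl in place of butyl on a saturated chain carbon, six bonds along the chain from an aromatic carbon. Going by the values given here, no measured step bears on a double bond in the chain; what is known is only that the chain length, from compound 1 through compound 3, never brought the tolerated concentration below the limit. On that basis compound 4 is expected to remain at or near the limit, so that the estimated step that the limit leaves unreadable from compound 3 to compound 4 is none beyond the scatter. For compound 4 in this assay the estimate is 60000 nM, with a range from 25000 nM to 150000 nM, and most likely again only a limit will be reported.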

Compound 4, minimum cytotoxic concentration: > 200000 nM
Compound 4 gave a limit, no number; the forecaster's own chance of this, stated with the estimate: 85%; middle value at least 3.3-fold (0.52 log units) away from the limit.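

In this assay compound 4 gives > 200000 nM, again a limit of the assay and not a number. No step from compound 1, compound 2 or compound 3 to compound 4 can be read, because those three also give only limits: the limit of > 50000 nM in this assay, at which 3 of the 4 values shown sit.

The compounds shown leave open at what concentration any of the four harms the cells, and whether the double bond in compound 4 changes that concentration.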